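Swapping Furan for Thiophene on a Weak Antiproliferative Scaffold

The source may report more compounds than this note shows. Statements on the series, on what has been measured and on what is new or still open speak of the compounds shown alone.

Measured compounds:
Compound 1, `C(=C/c1cccs1)\c1cc(-c2cccs2)cc(-c2cccs2)n1`: 118000 nM
Compound 2, `c1coc(-c2cc(-c3cccs3)nc(-c3cccs3)c2)c1`: 118000 nM

Both compounds were tested in a functional assay on HCT-15 cells (Homo sapiens) for antiproliferative activity; a higher number here means that more compound is needed for the effect, a lower number that less compound is needed. Compound 1 gives 118000 nM. Compound 2 gives 118000 nM, which stands level with compound 1 at the digits shown; the two values lie within the scatter of the measurement, so nothing can be said about any order between them. Both are weak.

Compound 3, `c1csc(-c2cc(-c3cccs3)nc(-c3cccs3)c2)c1`, has not yet been measured in this assay. It differs from compound 2 in one place: thiophen-2-yl in place of furan-2-yl on an aromatic carbon. Going by the values given here, no pair of measured compounds differing in a single place is available, so there is no measured step to lean on. The two measured values show that exchanging the aryl groups around the shared core has left the read-out unchanged within the scatter. On that basis a step from compound 2 to compound 3 that stays within the scatter is expected, in no particular direction. Compound 3 is therefore estimated at 118000 nM, with a range from 50000 nM to 280000 nM, corresponding to an expected step of no change at the digits printed from compound 2 to compound 3 (within the scatter).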

Compound 3, half-maximal effective concentration: 118000 nM
Compound 3: the middle estimate sits on the measured number at the digits printed; measured number inside the range.
By their numbers in this assay, from the lowest: compounds 1, 2 and 3 (each within the scatter of the next).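

In this assay, going by these compounds alone, putting thiophen-2-yl in place of furan-2-yl on the aromatic carbon opposite the ring nitrogen gives no change at the digits printed from compound 2 to compound 3 (within the scatter) and so provides the first measured step at this position: with thiophen-2-yl groups on the rest of the core, these two five-membered aromatic rings with one hetero atom cannot be told apart here. A second step, on another aromatic carbon of the shared core, replaces 2-(thiophen-2-yl)ethenyl with thiophen-2-yl and gives no change at the digits printed from compound 1 to compound 3 (within the scatter), so the read-out also fails to separate these two groups at that place. Nothing available bears on why the three values coincide.

Within the data shown here, all three compounds stay at the same weak level, so these steps show only that these particular aryl groups are interchangeable in this read-out, and they do not show whether the position can affect it at all. Going by these compounds, it remains open whether an amine, a carboxylic acid or a longer alkyl chain on the carbon opposite the ring nitrogen would leave the number where it stands or move it beyond the scatter.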